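This account rests on a few compounds, and the source may have more. Where it says the series, first, only, none or still open, it means among the compounds named here.

Measured compounds:
Compound 1, `COc1ccc(NC(=O)Nc2nc(Sc3c[nH]c4ccccc34)cc(N3CCN(Cc4ccccc4)CC3)n2)cc1` — 42300 nM
Compound 2, `O=C(Nc1ccccc1)Nc1nc(Nc2ccccc2)cc(Sc2c[nH]c3ccccc23)n1` — > 50000 nM

For the measured compounds named here, in a functional assay on A549 cells (Homo sapiens) for inhibition, with a stated time of 72 h (on this read-out higher numbers stand for weaker inhibition and lower numbers for stronger inhibition), compound 1 gives 42300 nM, and this is the only actual number that the series holds. Compound 2 gives > 50000 nM, which is a limit of this assay and not a number. The position of compound 1 is therefore fixed only loosely: it sits close to the limit of > 50000 nM in this assay, at which 1 of the 2 values shown sits, and nothing else in the set offers a second number to compare it with.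

Compound 3, `Cc1ccc(C)c(NC(=O)Nc2nc(Sc3c[nH]c4ccccc34)cc(N3CCN(Cc4ccccc4)CC3)n2)c1`, differs from compound 1 in one place: 2,5-dimethylphenyl in place of 4-methoxyphenyl on an amide-type nitrogen. The 4-methoxyphenyl leaves and a 2,5-dimethylphenyl enters on an amide-type nitrogen whose other neighbour is a carbonyl carbon, while the rest of the shared core is untouched. Going by the values given here, no pair of measured compounds traces this kind of exchange, so the size of the step has to be guessed. The expectation is a step of about a 1.1-fold lower number from compound 1 to compound 3 (0.02 log units; within the scatter), that is, nothing beyond the usual scatter in this assay, in either direction. Compound 3 is accordingly estimated at 40000 nM, with a range from 15000 nM to 100000 nM.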

Compound 3, half-maximal inhibitory concentration: > 50000 nM
Compound 3 ended at the assay's limit; the forecaster's own chance of this, stated with the estimate: 40%; middle value at least 1.2-fold (0.09 log units) from the limit.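

In this assay compound 3 gives > 50000 nM, which is a limit of the assay and not a number. Exchanging 4-methoxyphenyl for 2,5-dimethylphenyl on the amide-type nitrogen gives an at least 1.1-fold higher number from compound 1 to compound 3 (0.07 log units; that floor lies within the scatter), so this position now has its first readable step, but that step shows only a floor lying within the scatter and no gain in inhibition from this exchange. The new value also adds to the weight of the series at the edge of the measurable range: the limit of > 50000 nM in this assay, at which 2 of the 3 values shown sit.

Going by these compounds, how far compound 3 lies beyond its limit stays unknown, so the true size of the step remains open. Also open, on these data alone, is whether a different kind of group on this amide-type nitrogen, such as a cyclohexyl ring or a phenyl ring carrying a carboxylic acid, would bring the number clearly below that of compound 1.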